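This account rests on a few compounds, and the source may have more. Where it says the series, first, only, none or still open, it means among the compounds named here.

Three compounds built on the core of compound 1 `COc1ccccc1/C=C/[C@@H]1CCCCN1` have been measured in a functional assay on MCF7 cells (Homo sapiens) for inhibition, read by MTT assay, with a stated time of 24 h; on this read-out lower numbers stand for stronger inhibition and higher numbers for weaker inhibition. Compound 1 gives 3.81 ug/mL. Compound 2 `CC(=O)c1ccc(/C=C/[C@@H]2CCCCN2)cc1` gives 2.7 ug/mL, and compound 3 `Cc1ccc(/C=C/[C@@H]2CCCCN2)cc1` gives 5.35 ug/mL. Among these numbers compound 3 holds the highest, yet its gap to compound 1 and its gap to compound 2 both lie within the scatter, so no order among the three can be claimed from them.

The step from compound 3 to compound 4 `COc1ccc(/C=C/[C@@H]2CCCCN2)cc1` is methoxy in place of methyl on an aromatic carbon. Among the measured compounds shown here, the one measured step that bears on a change on that aromatic carbon is a 2.0-fold higher number from compound 2 to compound 3 (0.30 log units; within the scatter), and it lies within the scatter. For the measured compounds named here, compound 1 carries a methoxy as well, but no single step joins it to compound 3 or to compound 4; its value and that of compound 3 are within the scatter of each other. Nothing measured here shows that a swap of this kind on that aromatic carbon moves the read-out beyond the scatter. Compound 4 is therefore expected to give 4.5 ug/mL, in a range from 2.3 ug/mL to 8.5 ug/mL. That estimate means a 1.2-fold lower number from compound 3 to compound 4 (0.08 log units; within the scatter), a step expected to stay within the scatter.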

Compound 4, half-maximal inhibitory concentration: 3.57 ug/mL
Compound 4: the middle estimate sits 1.3-fold (0.10 log units) above what was measured, and the stated range covers the measured number.
By their numbers in this assay, from the lowest: compounds 2, 4, 1 and 3 (each within the scatter of the next).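

In this assay, methoxy in place of methyl on this aromatic carbon gives a 1.5-fold lower number from compound 3 to compound 4 (0.18 log units; within the scatter), and methoxy in place of acetyl on the same carbon gives a 1.3-fold higher number from compound 2 to compound 4 (0.12 log units; within the scatter). With these two steps, the three groups seen at this place, on the six-membered aromatic ring and para to a group of 8 heavy atoms, are joined pair by pair, and none of the steps leaves the scatter, so methyl, methoxy and acetyl cannot be put in any order here, and the hydrogen-bond acceptor that methoxy has and methyl lacks comes with no change that can be read. No measurement of any other kind is at hand that could account for these numbers.

Going by these compounds, whether any group on this aromatic carbon can move the number beyond the scatter remains open, for an amine, a carboxylic acid or a longer chain would each be a further test of that. Also open is how the read-out answers to changes at other places on the shared core, which the single steps shown here do not touch.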